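This account rests on a few compounds, and the source may have more. Where it says the series, first, only, none or still open, it means among the compounds named here.

Measured in a functional assay on Huh-7 cells (Homo sapiens) for cytotoxicity, read by MTT assay, with a stated time of 72 h; a lower number here means that less compound is tolerated, a higher number that more compound is tolerated:

Compound 1 `C1CCCC2(CC1)OOC1(CCCCCC1)OO2`: > 100 ug/mL
Compound 2 `COc1ccc(S(=O)(=O)N2CCC3(CC2)OOC2(CCCC2)OO3)cc1`: > 100 ug/mL
Compound 3 `CCCS(=O)(=O)N1CCC2(CC1)OOC(C)(CC)OO2`: > 100 ug/mL

Each of these entries is a limit of the assay and not a number. Compound 3 reads > 100 ug/mL, so it has no exact value to compare, and its standing is shared with the other two: the limit of > 100 ug/mL in this assay, at which 3 of the 3 values shown sit. Compound 1 and compound 2 look quite different from compound 3, yet the measurements do not separate the three.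

Compound 4 `CCCS(=O)(=O)N1CCC2(CC1)OOC(C)(C1CC1)OO2` changes compound 3 in one place, with cyclopropyl in place of ethyl on a saturated ring carbon, between two ring oxygen atoms: cyclopropyl in place of ethyl on a saturated ring carbon. Within the data shown here, no pair of measured compounds differs by a single change, so nothing shows directly how large such a step can be in this assay. Among the measured compounds shown here, the expectation therefore leans on the closest relative, compound 3 at > 100 ug/mL, and on the fact that no measured compound has yet given a number. The expected change is a step that the limit leaves unreadable from compound 3 to compound 4, which means no expected shift in either direction beyond the usual scatter. The assay is also expected, more likely than not, to report only a limit again. For compound 4 the estimated value is 120 ug/mL, with an expected range from 60 ug/mL to 300 ug/mL.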

Compound 4, half-maximal cytotoxic concentration: > 100 ug/mL
Compound 4 gave a limit, no number (the forecaster's own chance of this, stated with the estimate: 80%); the middle value is on the limit's open side.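

Compound 3 and compound 4 both give a limit and not a number, so the change of ethyl to cyclopropyl yields no readable step: the limit of > 100 ug/mL in this assay, at which 4 of the 4 values shown sit. The compounds shown leave open at what concentration any of them would give a number in this assay, and whether cyclopropyl in place of ethyl matters there.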